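Cyclooctyl replacing phenyl on the saturated ring carbon

The source may report more compounds than this note shows. Statements on the series, on what has been measured and on what is new or still open speak of the compounds shown alone.

Compound 1 `O=C1Nc2c(ccc(F)c2F)C1(c1ccccc1)c1ccc(O)cc1` gives 8.9 nM in a functional assay on PC-3 cells (Homo sapiens) for cytotoxicity, read by WST assay, with a stated time of 72 h (on this read-out higher numbers stand for weaker inhibition and lower numbers for stronger inhibition), and stands highest of the two single numbers in the series. For the measured compounds named here, its nearest neighbour is compound 2 `O=C1Nc2c(ccc(F)c2F)C1(c1ccc(O)cc1)c1cccs1`, which gives 0.3 nM; the step of a 30-fold lower number from compound 1 to compound 2 (1.47 log units; beyond the scatter) is the only one-place step with a number on both sides. Compound 3 `O=C1Nc2c(ccc(F)c2F)C1(c1ccc(O)cc1)C1CCCCC1` has three entries in this assay, 9.2 nM; 32 nM; > 1000 nM (3 entries), which scatter widely. The third of these entries for compound 3 is a limit of the assay, not a number. Compound 4 `O=C1Nc2c(ccc(F)c2F)C1(c1ccc(O)cc1)C1CCCCCCC1` differs from compound 1 by cyclooctyl in place of phenyl on a saturated ring carbon. Going by the values given here, no measured step covers this change directly: the step from compound 1 to compound 2 exchanges one aromatic ring for another, whereas here a non-aromatic ring enters. The nearest guide is the several entries of compound 3 in this assay, 9.2 nM; 32 nM; > 1000 nM (3 entries), where compound 3 spreads across two single numbers and a limit. A step towards higher numbers, beyond the scatter, is therefore expected, a 5.1-fold higher number from compound 1 to compound 4 (0.70 log units; beyond the scatter), with wide uncertainty. Compound 4 is estimated at 45 nM, between 8 nM and 400 nM.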

Compound 4, half-maximal inhibitory concentration: > 1000 nM
Compound 4: no number, only a limit; the forecaster's own chance of this, stated with the estimate: 20%; middle value at least 22-fold (1.34 log units) from the limit.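

In this assay compound 4 gives > 1000 nM, which is a limit of the assay and not a number. For the compounds shown here, this is the first one-place change at this saturated ring carbon to move towards higher numbers, with an at least 110-fold higher number from compound 1 to compound 4 (2.05 log units; beyond the scatter) and an at least 3300-fold higher number from compound 2 to compound 4 (3.52 log units; beyond the scatter), so the position that carries phenyl and thiophen-2-yl at low numbers does not hold the same reading with cyclooctyl. Compound 3, with a non-aromatic ring at this place, goes against a clean split between aromatic and non-aromatic rings, as its entries run from single numbers to a limit: the several entries of compound 3 in this assay, 9.2 nM; 32 nM; > 1000 nM (3 entries).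

The compounds shown do not separate the size of the entering ring from the absence of an aromatic ring. On these data alone, how an open octyl chain, or a cyclohexyl ring bearing an amine or a carboxylic acid, would read at this place remains open.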